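Stereochemistry and a benzyloxy swap on a quinuclidine triazole

The compounds below may be only part of what the source reports. "The series", "measured", "known", "first", "only" and "open" are said of these compounds alone.

The series rests on a shared core, shown for compound 1 as `Fc1cccc(-c2cn(C3CN4CCC3CC4)nn2)c1`. In an assay on HEK293 cells for displacement of a labelled ligand from Neuronal acetylcholine receptor; alpha4/beta2 (Homo sapiens), read by scintillation counting, with a stated time of 120 min (a lower number here means a stronger inhibitor, a higher number a weaker inhibitor), compound 1 gives 748 nM. Compound 2, `Fc1ccc(COc2cccc(-c3cn(C4CN5CCC4CC5)nn3)c2)cc1`, carries the change (4-fluorobenzyl)oxy in place of fluoro on an aromatic carbon and in this assay compound 2 gives 1010 nM, so that a 1.4-fold higher number from compound 1 to compound 2 (0.13 log units; within the scatter). Compound 3, `Fc1cccc(-c2cn([C@H]3CN4CCC3CC4)nn2)c1`, differs from compound 1 only in the way (the two compounds have the same atoms and bonds; at least one stereo element is drawn with a configuration in one of them and without one in the other: 1 of 3 stereo elements differ; a stereocentre at a saturated ring carbon is drawn without a configuration in compound 1 and R in compound 3), and in this assay compound 3 gives 5200 nM; the result is a 7.0-fold higher number from compound 1 to compound 3 (0.84 log units; beyond the scatter). The only thing that can be pointed to for this step is the fact that one of compounds 1 and 3 is drawn with a defined configuration and the other without, at the place where they differ, since the two compounds share every atom and bond. Compound 3 thus has the highest number of the three measured compounds, and its gap to compound 2 is also beyond the scatter.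

Compound 4, `Fc1ccc(COc2cccc(-c3cn([C@H]4CN5CCC4CC5)nn3)c2)cc1`, has not been measured. It stands to compound 3 as compound 2 stands to compound 1: the change is (4-fluorobenzyl)oxy in place of fluoro on an aromatic carbon, and the place line is the same word for word in both pairs, so it is the same change made on the core of compound 3 rather than on that of compound 1. The earlier step, a 1.4-fold higher number from compound 1 to compound 2 (0.13 log units; within the scatter), stayed within the scatter, so the estimate for compound 4 is built from compound 3 with 5200 nM and a step of about the same size. The expected step is a 1.3-fold higher number from compound 3 to compound 4 (0.13 log units; within the scatter). The estimate for compound 4 in this assay is 7000 nM, with a likely range from 3000 nM to 16000 nM.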

Compound 4, inhibition constant: 6390 nM
Estimate against measurement, compound 4: 1.1-fold (0.04 log units) above, within the range that was stated.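

Carried onto the second core in this assay, the swap of (4-fluorobenzyl)oxy for fluoro gives a 1.2-fold higher number from compound 3 to compound 4 (0.09 log units; within the scatter), and the two steps for this change agree: the same change on two cores in this assay, a 1.4-fold higher number (0.13 log units; within the scatter) from compound 1 to compound 2 and a 1.2-fold higher number (0.09 log units; within the scatter) from compound 3 to compound 4, 1.1-fold (0.04 log units) apart, within the scatter of two such steps. The swap thus carries across these two cores as a change that leaves the number where it was, while the change in drawn configuration stays beyond the scatter with the larger group in place, as a 6.3-fold higher number from compound 2 to compound 4 (0.80 log units; beyond the scatter), and the one thing that can be pointed to for that step is this: the fact that one of compounds 2 and 4 is drawn with a defined configuration and the other without, at the place where they differ. This does not show that other groups would carry across in the same way, since it rests on two pairs and one swap, and neither step is large enough to show a real effect of the swap on either core, nor do the data say what the compounds drawn without a configuration contain.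

The compounds shown leave open what the S configuration at that saturated ring carbon would give, on either the fluoro or the (4-fluorobenzyl)oxy compound. They also leave open whether an amine, a carboxylic acid or a longer chain at the same aromatic carbon would behave alike on the two cores.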